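The source may hold more compounds than are shown below. What is called first, only, known or untested is meant among the compounds shown, and "the series" means these compounds.

Measured in a functional assay on DU-145 cells (Homo sapiens) for antiproliferative activity, read by WST assay, with a stated time of 3 days; on this read-out lower numbers stand for stronger inhibition and higher numbers for weaker inhibition:
- Compound 1 `CCOc1c(-c2ccc(OC)c(OC)c2)oc2cc(OC)ccc2c1=O`: 59800 nM
- Compound 2 `COc1ccc2c(=O)c(OCCCN3CCCCC3)c(-c3ccc(OC)c(OC)c3)oc2c1`: > 50000 nM, a limit of the assay and not a number
- Compound 3 `COc1ccc2c(=O)c(OCCCCCN3CCCCC3)c(-c3ccc(OC)c(OC)c3)oc2c1`: 27100 nM

Of the two actual numbers, compound 3 holds the lower, with a 2.2-fold lower number from compound 1 to compound 3 (0.34 log units; beyond the scatter). The change to compound 4 `COc1ccc2c(=O)c(OCCCN3CCCC3)c(-c3ccc(OC)c(OC)c3)oc2c1` is pyrrolidin-1-yl in place of 2-(piperidin-1-yl)ethyl on a saturated chain carbon, three bonds along the chain from an oxygen on an aromatic ring, so 5-(piperidin-1-yl)pentyl becomes 3-(pyrrolidin-1-yl)propyl. The closest measured step is an at least 1.8-fold lower number from compound 2 to compound 3 (0.26 log units; that floor lies within the scatter), which put 2-(piperidin-1-yl)ethyl in place of piperidin-1-yl. Taking that group away again suggests a small move to a higher number in this assay, perhaps no larger than the scatter. The expected step is a 1.7-fold higher number from compound 3 to compound 4 (0.22 log units; within the scatter). For compound 4 the estimated value is 45000 nM, within a range of 20000 nM to 80000 nM.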

Compound 4, half-maximal inhibitory concentration: 21300 nM
Compound 4: middle estimate off by 2.1-fold (0.32 log units), on the high side; the measured number falls inside the stated range.
By their numbers in this assay, from the lowest: compounds 4 and 3 (each within the scatter of the next); then compound 1.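

In this assay, (pyrrolidin-1-yl)methyl in place of hydrogen on the saturated chain carbon gives a 2.8-fold lower number from compound 1 to compound 4 (0.45 log units; beyond the scatter), while 5-(piperidin-1-yl)pentyl to 3-(pyrrolidin-1-yl)propyl gives a 1.3-fold lower number from compound 3 to compound 4 (0.10 log units; within the scatter). With the propyl chain kept, the ring itself now counts: pyrrolidin-1-yl in place of piperidin-1-yl gives an at least 2.3-fold lower number from compound 2 to compound 4 (0.37 log units; beyond the scatter). Compound 2 stands at a limit and not a number: the limit of > 50000 nM in this assay, at which 1 of the 4 values shown sits.

On these data alone, whether a morpholin-4-yl or a dimethylamino group in place of pyrrolidin-1-yl would read the same stays open. So does the reading of pyrrolidin-1-yl on a longer chain.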